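The source may report more compounds than this note shows. Statements on the series, on what has been measured and on what is new or still open speak of the compounds shown alone.

Two esters on a shared core were tested in a functional assay on MCF7 cells (Homo sapiens) for inhibition, read by MTT assay, with a stated time of 72 h; a lower number here means a stronger inhibitor, a higher number a weaker inhibitor. Compound 1 `O=C(OC1(C(=O)Nc2ccc([N+](=O)[O-])cc2)CCCCC1)c1ccc(Br)cc1` gives 237 nM there. Within the data shown here, compound 2 `O=C(/C=C/c1ccccc1)OC1(C(=O)Nc2ccc([N+](=O)[O-])cc2)CCCCC1` gives 57.6 nM, and the change a 4.1-fold lower number from compound 1 to compound 2 (0.61 log units; beyond the scatter) is the only step so far; on this basis compound 2 stands lowest of the two numbers, with compound 1 as its nearest neighbour.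

Compound 3 `CC(=O)OC1(C(=O)Nc2ccc([N+](=O)[O-])cc2)CCCCC1` has not been measured. The difference from compound 2 is methyl in place of 2-phenylethenyl on a carbonyl carbon. Among the measured compounds shown here, the one measured step bears on it only in that it also varies the group on this carbonyl carbon: there the move to 2-phenylethenyl brought the number down beyond the scatter, and the present move takes that group away and leaves a single carbon in its place. For the measured compounds named here, no measured pair shows a methyl ester, so the direction is taken from that one step, and a rise in this assay is expected, probably larger than the scatter. For compound 3 the estimate is 450 nM, with a range from 120 nM to 1800 nM, meaning an expected step of a 7.8-fold higher number from compound 2 to compound 3 (0.89 log units; beyond the scatter).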

Compound 3, half-maximal inhibitory concentration: 403 nM
Compound 3: middle estimate off by 1.1-fold (0.05 log units), on the high side; measured number inside the range.
By their numbers in this assay, from the lowest: compound 2; then compounds 1 and 3 (each within the scatter of the next).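

Replacing 2-phenylethenyl with methyl on this carbonyl carbon gives a 7.0-fold higher number from compound 2 to compound 3 (0.84 log units; beyond the scatter) in this assay, so the low number of compound 2 is lost when only a single carbon remains at this position. The comparison with the bromo ester gives a 1.7-fold higher number from compound 1 to compound 3 (0.23 log units; within the scatter), which means that compound 1 and compound 3 cannot be told apart here, even though 4-bromophenyl carries an aromatic ring and methyl has none; among these three esters, having an aromatic ring on this carbonyl carbon therefore does not by itself go with a low number, and compound 1 stands against any such reading. Nothing available explains why 2-phenylethenyl stands apart from the other two groups.

The compounds shown do not separate the contribution of the double bond in 2-phenylethenyl from that of its ring, a question that a saturated 2-phenylethyl group or a plain phenyl group on the same carbonyl carbon would address. They also leave open how a longer alkyl chain or a group bearing an amine would behave at this position, and whether the order of these esters would hold on a different core.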